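A few compounds are considered here, and "the series" means these few. Any claim that something is new, unique, unknown or untested is made for them only; others in the source may bear on it.

Within the data shown here, in a physicochemical assay for solubility, read by nephelometry, in phosphate buffer, measured as kinetic solubility, at pH 6.5 (on this read-out lower numbers stand for lower solubility and higher numbers for higher solubility), compound 1 `O=C(Nc1ccc(F)c(-c2nc3ncccc3o2)c1)c1ccoc1` gives 6.3 ug/mL and compound 2 `Cc1ccc(NC(=O)c2ccoc2)cc1-c1nc2ncccc2o1` gives 6.3 ug/mL so compound 2 stands level with compound 1 on the numbers so far. Compound 3 `Cc1ccc(NC(=O)c2occc2C)cc1-c1nc2ncccc2o1` differs from compound 2 in a single place: 3-methylfuran-2-yl in place of furan-3-yl on a carbonyl carbon.

Among the measured compounds shown here, only one measured step is available as a guide. It shows no change at the digits printed from compound 1 to compound 2 (within the scatter) for methyl in place of fluoro on an aromatic carbon. That step also brings in a methyl, but at another place, so it bears on the present change only loosely. For the measured compounds named here, no measured pair yet varies the group on the carbonyl carbon, and the size of this change is therefore poorly constrained. With that single step as the guide, no shift beyond the scatter is expected in this assay and no direction is firmly supported. The expected step is a 1.3-fold lower number from compound 2 to compound 3 (0.10 log units; within the scatter) and the range is kept wide. For compound 3 the estimated value is 5 ug/mL with an expected range from 2 ug/mL to 14 ug/mL (an estimate, not yet a measurement).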

Compound 3, solubility: < 1.6 ug/mL
Compound 3: no number, only a limit (the forecaster's own chance of this, stated with the estimate: 10%); middle value at least 3.1-fold (0.49 log units) from the limit.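

In this assay, among these compounds, the group on the carbonyl carbon is the first place where a single change moves the read-out beyond the scatter: 3-methylfuran-2-yl in place of furan-3-yl gives an at least 3.9-fold lower number from compound 2 to compound 3 (0.59 log units; beyond the scatter), whereas methyl in place of fluoro on an aromatic carbon gave no change at the digits printed from compound 1 to compound 2 (within the scatter). Compound 3 reads < 1.6 ug/mL in this assay, which is a limit of the assay and not a number. The step is thus a minimum, and its full size cannot be read from the series so far: the limit of < 1.6 ug/mL in this assay, at which 1 of the 3 values shown sits.

The change carries two differences at once, the added methyl and the different attachment of the furan, and the compounds shown leave open which of the two accounts for the step. Also open, from the compounds shown here alone, is how the read-out in this assay would respond to an amine or a carboxylic acid on the group at the carbonyl carbon, and whether the step seen here would hold with fluoro in place of methyl on the aromatic carbon.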